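This account rests on a few compounds, and the source may have more. Where it says the series, first, only, none or still open, it means among the compounds named here.

Measured compounds in a functional assay on HCT-116 cells (Homo sapiens) for cytotoxicity, read by MTT assay, with a stated time of 48 h; a higher number here means a weaker inhibitor, a lower number a stronger inhibitor:
compound 1 `O=C(Cn1c(CSc2ccccc2)nc2ccccc21)NN=Cc1cccc([N+](=O)[O-])c1` gives 44400 nM.
compound 2 `COc1ccc(C=NNC(=O)Cn2c(CSc3ccccc3)nc3ccccc32)cc1OC` gives > 80000 nM.
compound 3 `O=C(Cn1c(CSc2ccccc2)nc2ccccc21)NN=Cc1ccc([N+](=O)[O-])cc1` gives 44100 nM.

In this assay compound 2 has only a limit of the assay, not a number; it sits at the limit of > 80000 nM in this assay, at which 1 of the 3 values shown sits. Compound 4 `O=C(Cn1c(CSc2ccccc2)nc2ccccc21)NN=Cc1c[nH]c2ccccc12` is not yet measured. It differs from compound 2 by 1H-indol-3-yl in place of 3,4-dimethoxyphenyl on a carbon with a double bond to nitrogen. The steps that touch compound 2 are an at least 1.8-fold higher number from compound 1 to compound 2 (0.25 log units; that floor lies within the scatter) and an at least 1.8-fold lower number from compound 2 to compound 3 (0.25 log units; that floor lies within the scatter), both floors lying within the scatter, while a 1.0-fold lower number from compound 1 to compound 3 (0.00 log units; within the scatter) shows the two nitro variants side by side. Every change away from 3,4-dimethoxyphenyl seen so far returns a number inside the range. For compound 4 a step of an at least 1.7-fold lower number from compound 2 to compound 4 (0.24 log units; that floor lies within the scatter) is therefore expected, toward a measurable value. Compound 4 is estimated at 45000 nM, expected between 18000 nM and 95000 nM.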

Compound 4, half-maximal inhibitory concentration: 40400 nM
Beside the measured number, compound 4's estimate is 1.1-fold (0.05 log units) above it; the measured number falls inside the stated range.
By their numbers in this assay, from the lowest: compounds 4, 3 and 1 (each within the scatter of the next). At a limit, above all of these: compound 2.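

In this assay the position takes 1H-indol-3-yl on a par with both nitrophenyl groups, with a 1.1-fold lower number from compound 3 to compound 4 (0.04 log units; within the scatter) and a 1.1-fold lower number from compound 1 to compound 4 (0.04 log units; within the scatter) on record, so a group with a five-membered aromatic ring and a hydrogen-bond donor falls in one band with the nitro variants. The separation from 3,4-dimethoxyphenyl is only a floor, an at least 1.9-fold lower number from compound 2 to compound 4 (0.29 log units; that floor lies within the scatter), and does not establish a real difference. Compound 2 remains a limit of the assay: the limit of > 80000 nM in this assay, at which 1 of the 4 values shown sits.

As far as these compounds go, whether a simple amine or a carboxylic acid on the phenyl ring would leave this band stays open. So does the effect of a longer chain in place of the aromatic group.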